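The source may hold more compounds than are shown below. What is called first, only, known or untested is meant among the compounds shown, and "the series" means these compounds.

Compound 1 `Cc1c(Cc2c(F)cccc2F)nc(N(C)C)[nH]c1=O`: > 89000 nM, a limit
Compound 2 `CCCN(CCC)c1nc(Cc2c(F)cccc2F)c(C)c(=O)[nH]1`: > 74000 nM, a limit

In an ADME assay on MT4 cells (Homo sapiens) for cytotoxicity, read by MTT assay, with a stated time of 4 days (on this read-out higher numbers stand for lower toxicity in this test and lower numbers for higher toxicity in this test), compound 2 has no number, only the limit > 74000 nM. Compound 1 likewise gives only the limit > 89000 nM.

Compound 3 `Cc1c(Cc2c(F)cccc2F)nc(N2CCCC2)[nH]c1=O` carries pyrrolidin-1-yl in place of dipropylamino on an aromatic carbon, (pyrrolidin-1-yl in place of dipropylamino on an aromatic carbon). Going by the values given here, the only measured step on this amino group is a step that the two limits leave unreadable from compound 1 to compound 2, so it offers no size to carry over. In this assay the expected step is a step that the limit leaves unreadable from compound 2 to compound 3, none beyond the scatter. The estimate for compound 3 is 82000 nM, with an expected range of 30000 nM to 120000 nM, and a limit is the likely report.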

Compound 3, half-maximal cytotoxic concentration: > 82000 nM
Compound 3 gave a limit, no number; the forecaster's own chance of this, stated with the estimate: 80%; the middle value lies on the limit itself.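

In this assay compound 3 gives only a limit, as do compound 1 and compound 2, so no step among these compounds can be read. Going by these compounds, whether the dimethylamino, dipropylamino and pyrrolidin-1-yl compounds differ at all in cytotoxicity stays open.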